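Amino in place of chloro: expected shift for compound 4

The compounds below may be only part of what the source reports. "The series", "measured", "known", "first", "only" and "open" are said of these compounds alone.

Measured so far:
compound 1, `ClCc1ccccc1Cn1cnc2c(Cl)nc(Cl)nc21`: 3310 nM
compound 2, `Nc1nc(Cl)c2ncn(Cc3ccc(CCl)cc3)c2n1`: 44700 nM
compound 3, `ClCc1ccc(Cn2cnc3c(Cl)nc(Cl)nc32)cc1`: 6920 nM

All three numbers come from a functional assay on SK-MEL-28 cells (Homo sapiens) for cytotoxicity, read by sulforhodamine B assay, with a stated time of 48 h; on this read-out higher numbers stand for weaker inhibition of growth and lower numbers for stronger inhibition of growth. Compound 1 gives the lowest number of the three; compound 3 stands nearest to it, at a gap beyond the scatter, and compound 2 stands furthest. Compound 4, `Nc1nc(Cl)c2ncn(Cc3ccccc3CCl)c2n1`, differs from compound 1 in one place: amino in place of chloro on an aromatic carbon. Among the compounds with values here, the single measured step that bears on this exchange runs the opposite way, a 6.5-fold lower number from compound 2 to compound 3 (0.81 log units; beyond the scatter), a modest step beyond the scatter. Applying the reverse of it to compound 1 should therefore raise the number, and the expected step is a 6.3-fold higher number from compound 1 to compound 4 (0.80 log units; beyond the scatter). Compound 4 is accordingly estimated at about 21000 nM, with a range from 8000 nM to 60000 nM.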

Compound 4, concentration for total growth inhibition: 20900 nM
Compound 4: middle estimate off by 1.0-fold (0.00 log units), on the high side, within the range that was stated.
By their numbers in this assay, from the lowest: compound 1; then compound 3; then compound 4; then compound 2.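

In this assay, amino in place of chloro on an aromatic carbon between two ring nitrogen atoms gives a 6.3-fold higher number from compound 1 to compound 4 (0.80 log units; beyond the scatter). The exchange can now be read on two cores rather than one, and its size barely differs between them: the same change on two cores in this assay, a 6.5-fold lower number (0.81 log units; beyond the scatter) from compound 2 to compound 3 and a 6.3-fold lower number (0.80 log units; beyond the scatter) from compound 4 to compound 1, 1.0-fold (0.01 log units) apart, within the scatter of two such steps

Only chloro and amino are shown at this position, so it remains open whether the number follows the loss of chloro or the identity of the entering group. A methoxy group or a methylamino group at this position would separate the two readings.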